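Swapping a Chlorophenyl for a Hydroxyphenyl: Expecting Compound 3

The source may hold more compounds than are shown below. What is called first, only, known or untested is meant among the compounds shown, and "the series" means these compounds.

Compound 1 `COc1cccc(/C=C2\CCC/C(=C\c3cccc(Cl)c3)C2=O)c1OC`: > 20000 nM
Compound 2 `COc1ccc(/C=C2\CCC/C(=C\c3ccccc3Cl)C2=O)cc1OC`: > 20000 nM

Both measurements come from a functional assay on A549 cells (Homo sapiens) for cytotoxicity, read by MTT assay, with a stated time of 72 h; a lower number here means a stronger inhibitor, a higher number a weaker inhibitor. For compound 1 the value > 20000 nM is a limit of the assay, not a number. For compound 2 the value > 20000 nM is likewise a limit. Compound 2 thus stands at the limit of > 20000 nM in this assay, at which 2 of the 2 values shown sit, so its potency is known only as weak. Compound 3 `COc1ccc(/C=C2\CCC/C(=C\c3ccc(O)cc3)C2=O)cc1OC` is not yet measured. It differs from compound 2 in one place: 4-hydroxyphenyl in place of 2-chlorophenyl on a double-bonded chain carbon bound to a double-bonded ring carbon. Among the compounds with values here, no step between two measured compounds is available to guide the size of this change, and the two measured values, being limits, give no direction either. The step from compound 2 to compound 3 is expected to be an at least 1.6-fold lower number from compound 2 to compound 3 (0.22 log units; that floor lies within the scatter), toward a somewhat stronger inhibitor, though with real doubt. For compound 3 the expected value is 12000 nM, with a range from 2500 nM to 40000 nM, and a fair chance that only a limit is again reported.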

Compound 3, half-maximal inhibitory concentration: > 20000 nM
Compound 3: a limit, no number; the forecaster's own chance of this, stated with the estimate: 45%; at least 1.6-fold (0.22 log units) between middle value and limit.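

In this assay compound 3 gives > 20000 nM, which is a limit and not a number. Compound 2 also stands at a limit, so no step can be read between compound 2 and compound 3. The compounds shown leave open whether 4-hydroxyphenyl or 2-chlorophenyl gives the stronger inhibitor, and all of them sit at the same place: the limit of > 20000 nM in this assay, at which 3 of the 3 values shown sit.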